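Chloro in place of methoxy on compound 1

This account rests on a few compounds, and the source may have more. Where it says the series, first, only, none or still open, it means among the compounds named here.

Measured so far in a functional assay on MCF7 cells (Homo sapiens) for antiproliferative activity, read by MTT assay, with a stated time of 48 h; a higher number here means a weaker inhibitor, a lower number a stronger inhibitor
- compound 1 `COc1ccc(C(=O)/C=C/c2cc(Br)cc(Br)c2Oc2c([N+](=O)[O-])cc(C(F)(F)F)cc2[N+](=O)[O-])cc1` gives 3.53 ug/mL
- compound 2 `COc1ccc(C(=O)/C=C/c2cccc(Br)c2Oc2c([N+](=O)[O-])cc(C(F)(F)F)cc2[N+](=O)[O-])cc1` gives 2.32 ug/mL

Compound 1 stands within the scatter of compound 2, so neither can be ranked. Compound 3 `O=C(/C=C/c1cc(Br)cc(Br)c1Oc1c([N+](=O)[O-])cc(C(F)(F)F)cc1[N+](=O)[O-])c1ccc(Cl)cc1` differs from compound 1 by chloro in place of methoxy on an aromatic carbon, para to a large group. For the measured compounds named here, the only measured step, a 1.5-fold lower number from compound 1 to compound 2 (0.18 log units; within the scatter), concerns hydrogen in place of bromo and so bears on this change only indirectly. No step beyond the scatter is therefore expected in this assay. The expected change is a 1.1-fold lower number from compound 1 to compound 3 (0.04 log units; within the scatter). For compound 3 the estimated value is 3.2 ug/mL, with an expected range from 1.2 ug/mL to 8.5 ug/mL.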

Compound 3, half-maximal inhibitory concentration: 6.76 ug/mL
Estimate against measurement, compound 3: 2.1-fold (0.32 log units) below; low and high end bracket the measured number.
By their numbers in this assay, from the lowest: compounds 2, 1 and 3 (each within the scatter of the next, the first and the last beyond it).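

In this assay, the first change shown on this ring, chloro in place of methoxy on an aromatic carbon para to a large group, gives a 1.9-fold higher number from compound 1 to compound 3 (0.28 log units; within the scatter) and so shows no step beyond the scatter at this position. One atom of chloro thus stands in for the methoxy, with its two heavy atoms, without a readable effect on the number. Nothing available explains this result.

Going by these compounds, whether an amine or a carboxylic acid here would move the number beyond the scatter stays open. So does whether chloro gives the same result on the core of compound 2.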